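This account rests on a few compounds, and the source may have more. Where it says the series, first, only, none or still open, it means among the compounds named here.

Compound 1 `COc1cc(N2C(=O)[C@@H](Oc3ccccc3)[C@H]2c2cccc3ccccc23)cc(OC)c1OC`: 53000 nM
Compound 2 `COc1cc([C@@H]2[C@H](Oc3ccccc3)C(=O)N2c2cc(OC)c(OC)c(OC)c2)ccc1O`: 32000 nM

In a functional assay on MCF7 cells (Homo sapiens) for antiproliferative activity, read by MTT assay, with stated times of 24 h and 72 h (on this read-out higher numbers stand for weaker inhibition and lower numbers for stronger inhibition), compound 2, at 32000 nM, stands within the scatter of compound 1. Compound 3 `COc1cc(N2C(=O)[C@@H](Oc3ccccc3)[C@H]2c2cc(O)c(OC)c([N+](=O)[O-])c2)cc(OC)c1OC` changes the same saturated ring carbon: a group of 12 heavy atoms (7 carbon, 1 nitrogen, 4 oxygen; one six-membered aromatic ring of carbon only) in place of a group of 9 heavy atoms (7 carbon, 2 oxygen; one six-membered aromatic ring of carbon only), on a saturated ring carbon. Going by the values given here, the only measured step at that carbon, a 1.7-fold lower number from compound 1 to compound 2 (0.22 log units; within the scatter), bears on this change but sets no direction. Any expectation in this assay is therefore weakly supported, and a moderate move toward stronger inhibition is expected from the entering group alone, as an estimated 4.0-fold lower number from compound 2 to compound 3 (0.60 log units; beyond the scatter). For compound 3 the estimate is 8000 nM, with an expected range of 800 nM to 40000 nM.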

Compound 3, half-maximal inhibitory concentration: 69000 nM
For compound 3 the middle estimate is 8.6-fold (0.94 log units) below the measured one; the measured number lies above the stated range.
By their numbers in this assay, from the lowest: compounds 2, 1 and 3 (each within the scatter of the next, the first and the last beyond it).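

Going by these compounds alone, at this saturated ring carbon, this assay now shows a first step beyond the scatter, a modest one toward weaker inhibition: a 2.2-fold higher number from compound 2 to compound 3 (0.33 log units; beyond the scatter). Against the naphthalen-1-yl group, the same entering group gives a 1.3-fold higher number from compound 1 to compound 3 (0.11 log units; within the scatter), so the three groups tried here span only a narrow band of high numbers. Nothing on hand accounts for the step from the 4-hydroxy-3-methoxyphenyl group.

Open, on these data alone, is whether an amine or a carboxylic acid on the aromatic ring at this carbon would shift the number further. Also open, as far as these compounds go, is whether any change at the phenoxy group would do more than changes at this carbon.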